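The source may hold more compounds than are shown below. What is called first, only, known or untested is meant among the compounds shown, and "the series" means these compounds.

Working notes on the series. The shared core of compound 1 `Cc1cc(C(F)(F)F)cc(OCc2c(-c3c(Cl)cccc3Cl)noc2C(C)C)n1` carries on the chain a trifluoromethyl-bearing aromatic ring; in a functional assay on HEK293 cells for agonist activity at Bile acid receptor (Homo sapiens), read by a luciferase reporter (on this read-out higher numbers stand for larger maximal responses and lower numbers for smaller maximal responses), compound 1 gives "not active" (no number reported), and no number accompanies that entry. Compound 2 `CC(Nc1ccc(C(=O)O)cc1)c1ccc(OCc2c(-c3c(Cl)cccc3Cl)noc2C2CC2)nc1C(F)(F)F` adds a (4-carboxyphenyl)amino group on the saturated chain carbon and in this assay compound 2 gives 49%. Among the measured compounds shown here, that is the only number in the set, so compound 2 stands alone and no ranking among measured compounds can be drawn.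

Compound 3 `CC(Oc1cccc(C(=O)O)c1)c1ccc(OCc2c(-c3c(Cl)cccc3Cl)noc2C2CC2)nc1C(F)(F)F` is the next entry to be measured in this assay. It differs from compound 2 as follows: 3-carboxyphenoxy in place of (4-carboxyphenyl)amino on a saturated chain carbon bound to an aromatic carbon and a saturated chain carbon. For the measured compounds named here, no pair of measured compounds shows a step of this kind, so there is no measured guide to its size or direction. With a single number in hand, the expectation is a step of modest size, and the direction cannot be fixed from these data; it may well stay within the usual scatter. The estimated step from compound 2 to compound 3 is a number 4 percentage points lower from compound 2 to compound 3 (within the scatter). In this assay compound 3 is expected to give about 45%, within a range of 15% to 80%.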

Compound 3, largest response reached (reported as efficacy), in percent of the reference or control that the assay uses: 49%
Estimate against measurement, compound 3: 4 percentage points below; measured number inside the range.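

Among the compounds shown here, on a saturated chain carbon bound to an aromatic carbon and a saturated chain carbon, 3-carboxyphenoxy in place of (4-carboxyphenyl)amino gives in this assay no change at the digits printed from compound 2 to compound 3 (within the scatter) and is the first one-place step read at this position. The exchange alters more than one feature at once: the amino nitrogen gives way to the phenoxy oxygen, the group's count goes from 2 hydrogen-bond donors to 1 hydrogen-bond donor, and the carboxy label goes from 4 to 3, yet the maximal response does not separate the two compounds. No measurement here gives an explanation for this outcome.

For the compounds shown here, the single step cannot show whether the two alterations each leave the response unchanged or whether they offset each other; 4-carboxyphenoxy or (3-carboxyphenyl)amino at the same carbon would pull them apart. Also open, on these data alone, is how much of the response depends on the carboxylic acid itself, which a plain phenoxy group or a nitrile in its place on the ring would address.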